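This account rests on a few compounds, and the source may have more. Where it says the series, first, only, none or still open, it means among the compounds named here.

Compound 1 `Nc1nc(N)c2c(-c3ccsc3)cn([C@@H]3O[C@H](CO)[C@@H](O)[C@H]3O)c2n1`, compound 2 `COc1nc(N)nc2c1c(-c1ccsc1)cn2[C@@H]1O[C@H](CO)[C@@H](O)[C@H]1O` and compound 3 `Nc1nc(N)c2c(-c3cc4ccccc4o3)cn([C@@H]3O[C@H](CO)[C@@H](O)[C@H]3O)c2n1` share a core, and compound 4 `COc1nc(N)nc2c1c(-c1cc3ccccc3o1)cn2[C@@H]1O[C@H](CO)[C@@H](O)[C@H]1O` has not yet been measured. In an ADME assay on MRC5 cells (Homo sapiens), read by MTT assay, with a stated time of 72 h (a higher number here means a weaker inhibitor, a lower number a stronger inhibitor), compound 1 gives > 100000 nM, which is a limit of the assay rather than a number. Compound 2 likewise gives > 100000 nM, also a limit. Going by the values given here, compound 3 gives 78500 nM, the only number among the three. The change from compound 1 to compound 2 is methoxy in place of amino on an aromatic carbon, and its step is a step that the two limits leave unreadable from compound 1 to compound 2, as the limit of > 100000 nM in this assay, at which 2 of the 3 values shown sit, shows. Compound 1 and compound 3 differ by 1-benzofuran-2-yl in place of thiophen-3-yl on an aromatic carbon, giving an at least 1.2-fold lower number from compound 1 to compound 3 (0.10 log units; that floor lies within the scatter). From compound 3 to compound 4 the same change is made, (methoxy in place of amino on an aromatic carbon), in the same surroundings. Among the compounds with values here, the one measured instance of this change, a step that the two limits leave unreadable from compound 1 to compound 2, gives no size to carry over. Compound 4 is expected to move little, an estimated step of a 1.1-fold higher number from compound 3 to compound 4 (0.06 log units; within the scatter). The estimate for compound 4 is 90000 nM, between 40000 nM and 200000 nM.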

Compound 4, half-maximal inhibitory concentration: 22700 nM
For compound 4 the middle estimate is 4.0-fold (0.60 log units) above the measured one; the measured number lies below the stated range.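

In this assay the swap of amino for methoxy has a readable size only with 1-benzofuran-2-yl in place, as a 3.5-fold lower number from compound 3 to compound 4 (0.54 log units; beyond the scatter) shows, and the same swap with thiophen-3-yl cannot be read, so one instance gives no rule for moving it between cores. Exchanging thiophen-3-yl for 1-benzofuran-2-yl with methoxy present gives an at least 4.4-fold lower number from compound 2 to compound 4 (0.64 log units; beyond the scatter) but, set beside the amino pair, its size may or may not carry over: the same change on two cores in this assay, an at least 1.2-fold lower number (0.10 log units; that floor lies within the scatter) from compound 1 to compound 3 and an at least 4.4-fold lower number (0.64 log units; beyond the scatter) from compound 2 to compound 4; the limit leaves it open whether they differ. The unreadable steps all trace back to one ceiling: the limit of > 100000 nM in this assay, at which 2 of the 4 values shown sit.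

As far as these compounds go, what remains open is whether an ethoxy or a methylamino group in the same place would behave like methoxy. A third aromatic group, such as phenyl, could test whether the pattern extends beyond these four compounds.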